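Enlarging the Amine Ring in Compound 1

The source may report more compounds than this note shows. Statements on the series, on what has been measured and on what is new or still open speak of the compounds shown alone.

Measured compounds:
compound 1 `CC1=C(c2cccc(O)c2)C(c2ccc(OC[C@H](C)N3CCCC3)cc2)Oc2ccc(O)cc21` gives 0.2 nM in a functional assay on MCF7 cells (Homo sapiens) for antiproliferative activity, read by CellTiter-Glo, with a stated time of 5 days; a lower number here means a stronger inhibitor, a higher number a weaker inhibitor
compound 2 `CC1=C(c2cccc(O)c2)C(c2ccc(OC[C@H](C)N3CC[C@@H](C)C3)cc2)Oc2cc(O)ccc21` gives 0.3 nM in this assay
compound 3 `CC1=C(c2ccc(F)cc2)C(c2ccc(OC[C@H](C)N3CC[C@@H](C)C3)cc2)Oc2ccc(O)cc21` gives 0.4 nM in this assay

Compound 1 carries the lowest of the three numbers in this assay, yet its nearest neighbour compound 2 and its furthest neighbour compound 3 both lie within the usual scatter of it, so the three compounds cannot be told apart on potency from these values.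

Compound 4 `CC1=C(c2cccc(O)c2)C(c2ccc(OC[C@H](C)N3CCCCCC3)cc2)Oc2ccc(O)cc21` has not yet been measured. It differs from compound 1 in one place: azepan-1-yl in place of pyrrolidin-1-yl on a saturated chain carbon bound to two saturated chain carbons. The shared core, the two phenol groups and the chain carrying the amine all stay as they are.

For the measured compounds named here, no measured pair shows this kind of change, so its effect can only be guessed. Given how closely compounds 1, 2 and 3 sit together, the step from compound 1 to compound 4 in this assay is expected to be small, at most a modest weakening, and quite possibly inside the scatter: a 1.8-fold higher number from compound 1 to compound 4 (0.24 log units; within the scatter). Compound 4 is therefore estimated at 0.35 nM, with a likely range from 0.12 nM to 1 nM.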

Compound 4, half-maximal inhibitory concentration: 0.2 nM
Compound 4: middle estimate off by 1.8-fold (0.24 log units), on the high side, and the stated range covers the measured number.
By their numbers in this assay, from the lowest: compounds 1, 4, 2 and 3 (each within the scatter of the next).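

In this assay the swap of pyrrolidin-1-yl for azepan-1-yl gives no change at the digits printed from compound 1 to compound 4 (within the scatter) and so brings no readable loss of potency. For the compounds shown here, at this saturated chain carbon, then, a seven-membered amine ring serves as well as a five-membered one, which the earlier compounds could not show, since none of them forms a pair that differs in this one place. Nothing measured here explains why the larger ring is accepted.

The compounds shown leave open how far this tolerance extends: whether piperidin-1-yl or morpholin-4-yl would sit in line with these two rings is unknown. From the compounds shown here alone, it is also open whether an open-chain amine such as dimethylamino, with no ring at all, would keep the potency of compound 1 and compound 4.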